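From Bromo to Iodo: A Halogen Swap

This account rests on a few compounds, and the source may have more. Where it says the series, first, only, none or still open, it means among the compounds named here.

Three compounds share a core that carries a six-membered aromatic ring of carbon only. Compound 1 `OCc1cc(F)cc(C2=NCCCC2)c1` bears a hydroxymethyl and a fluoro on that ring, compound 2 `Brc1cccc(C2=NCCCC2)c1` bears a single bromo, and compound 3 `Brc1cc(Br)cc(C2=NCCCC2)c1` bears two bromo groups. In an assay on cell membranes for displacement of a labelled ligand from Neuronal acetylcholine receptor; alpha4/beta2 (Rattus norvegicus), read by radioligand binding, with a stated time of 30 min (on this read-out lower numbers stand for stronger inhibition and higher numbers for weaker inhibition), compound 1 gives 744 nM, compound 2 gives 5020 nM, and compound 3 gives 18800 nM. Compound 2 thus holds the second highest of the three numbers: compound 3 lies nearest, a 3.7-fold higher number from compound 2 to compound 3 (0.57 log units; beyond the scatter), while compound 1 lies furthest, with the lower number.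

Compound 4 `Ic1cccc(C2=NCCCC2)c1` differs from compound 2 in one place: iodo in place of bromo on an aromatic carbon. Within the data shown here, only one measured step touches a halogen at this spot, and only loosely: a 3.7-fold higher number from compound 2 to compound 3 (0.57 log units; beyond the scatter) came from adding a second bromo, not from exchanging one halogen for another. Among the measured compounds shown here, no measured step trades bromo for iodo, so the data give no direct guide. The exchange is a one-atom swap of one halogen for another, and the expected step in this assay is therefore small, a 1.3-fold lower number from compound 2 to compound 4 (0.10 log units; within the scatter), within the scatter. Compound 4 is expected to give about 4000 nM in this assay, with a range from 1500 nM to 12000 nM.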

Compound 4, inhibition constant: 3790 nM
Beside the measured number, compound 4's estimate is 1.1-fold (0.02 log units) above it; low and high end bracket the measured number.
By their numbers in this assay, from the lowest: compound 1; then compounds 4 and 2 (each within the scatter of the next); then compound 3.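

In this assay, exchanging bromo for iodo on an aromatic carbon, meta to a group of 6 heavy atoms, gives a 1.3-fold lower number from compound 2 to compound 4 (0.12 log units; within the scatter), so the two halogens cannot be told apart at this position. Among these compounds, the earlier compounds showed only what adding a second bromo does, a 3.7-fold higher number from compound 2 to compound 3 (0.57 log units; beyond the scatter), a step beyond the scatter; this pair is the first to show that exchanging one halogen for another at the same spot leaves the number within the scatter. The data shown offer no independent measurement that could account for this result.

The compounds shown leave open whether the same tolerance extends to a smaller halogen such as chloro, or whether it ends once the halogen gives way to a different kind of group, such as an amine, a nitrile or a carboxylic acid. Among the compounds shown here, they also leave open what the hydroxymethyl and the fluoro of compound 1 each contribute, since the two groups appear only together and no compound here carries either one alone.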